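Swapping thiophen-2-yl for pyridin-3-yl on a chlorophenyl core

This account rests on a few compounds, and the source may have more. Where it says the series, first, only, none or still open, it means among the compounds named here.

Three measured compounds share a core bearing a 4-hydroxyphenyl group. In an assay on isolated protein for inhibition of DNA topoisomerase 1 (Homo sapiens), with a stated time of 30 min, tested at 100 uM (on this read-out higher numbers stand for a stronger effect at the one concentration tested and lower numbers for a weaker effect), compound 1 `Oc1ccc(-c2cc(-c3ccc(Cl)cc3)nc(-c3cccnc3)c2)cc1` gives 18.8%. Compound 2 `Oc1ccc(-c2cc(-c3ccc(Cl)cc3)nc(-c3cccs3)c2)cc1` gives 38.8% in this assay, and compound 3 `Oc1ccc(-c2cc(-c3cccc(Cl)c3)nc(-c3cccs3)c2)cc1` gives 52.4%, the highest of the three. Compound 2 and compound 3 have the same atoms joined differently: 3-chlorophenyl in place of 4-chlorophenyl on an aromatic carbon, a change that gave a number 13.6 percentage points higher from compound 2 to compound 3 (beyond the scatter). Compound 1 differs from compound 2 by pyridin-3-yl in place of thiophen-2-yl on an aromatic carbon, and that change gave a number 20 percentage points lower from compound 2 to compound 1 (beyond the scatter).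

Compound 4 `Oc1ccc(-c2cc(-c3cccnc3)nc(-c3cccc(Cl)c3)c2)cc1` awaits measurement in this assay. It differs from compound 3 by pyridin-3-yl in place of thiophen-2-yl on an aromatic carbon. This is the same kind of change as that from compound 2 to compound 1, though the surroundings differ: in compound 4 the entering group sits meta to a 3-chlorophenyl group, whereas in compound 1 it sits meta to a 4-chlorophenyl group, the two cores differing as compound 2 differs from compound 3. Compound 4 is expected to show a step of a number 20.4 percentage points lower from compound 3 to compound 4 (beyond the scatter) beside the earlier one, because the earlier step of a number 20 percentage points lower from compound 2 to compound 1 (beyond the scatter) was a clear fall. Compound 4 is therefore estimated at 32%, between 15% and 50%.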

Compound 4, a percentage reported as inhibition, at one concentration (the size of the read-out at that concentration, not a potency): 55.2%
Compound 4: the middle estimate sits 23.2 percentage points below what was measured; the measured number lies above the stated range.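

On the core carrying a 3-chlorophenyl group, pyridin-3-yl in place of thiophen-2-yl gave a number 2.8 percentage points higher from compound 3 to compound 4 (within the scatter), so the fall seen on the core carrying a 4-chlorophenyl group did not carry across: the same change on two cores in this assay, a number 20 percentage points lower (beyond the scatter) from compound 2 to compound 1 and a number 2.8 percentage points higher (within the scatter) from compound 3 to compound 4, 22.8 percentage points apart, beyond the scatter of two such steps. Read the other way, 3-chlorophenyl in place of 4-chlorophenyl gave a number 36.4 percentage points higher from compound 1 to compound 4 (beyond the scatter), a larger step with pyridin-3-yl than with thiophen-2-yl: the same change on two cores in this assay, a number 13.6 percentage points higher (beyond the scatter) from compound 2 to compound 3 and a number 36.4 percentage points higher (beyond the scatter) from compound 1 to compound 4, 22.8 percentage points apart, beyond the scatter of two such steps. These two gaps are the same four compounds read in two ways, so they show that in this set the outcome of each change depends on the group at the other place, but they do not show why, nor whether this holds beyond these compounds or at any other concentration.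

The compounds shown leave open what a plain phenyl, a furan-2-yl or an amine would give in place of the thiophen-2-yl or pyridin-3-yl group. They also leave open what a methoxy group would give in place of the hydroxyl of the 4-hydroxyphenyl group.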